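The source may hold more compounds than are shown below. What is called first, only, known or untested is meant among the compounds shown, and "the series" means these compounds.

Measured so far in a functional assay on HCT-116 cells (Homo sapiens) for antiproliferative activity, read by sulforhodamine B assay, with a stated time of 48 h; on this read-out higher numbers stand for weaker inhibition and lower numbers for stronger inhibition:

compound 1 `COc1cc(O)c(C(=O)/C=C/c2ccc(Br)cc2)c(OC)c1` — 14000 nM
compound 2 `COc1cc(OC)c(C(=O)/C=C/c2ccc(Br)cc2)c(OCC=C(C)C)c1` — 2100 nM

Compound 2 holds the lowest of the two numbers; its nearest neighbour is compound 1, and the single step shown, a 6.7-fold lower number from compound 1 to compound 2 (0.82 log units; beyond the scatter), is the only one measured in this assay. Compound 3 `COc1cc(OC)c(C(=O)/C=C/c2cc(Cl)cc(Cl)c2)c(OCC=C(C)C)c1` differs from compound 2 by 3,5-dichlorophenyl in place of 4-bromophenyl on a double-bonded chain carbon bound to a double-bonded chain carbon. Among the measured compounds shown here, no measured step touches this part of the molecule, so the step of a 6.7-fold lower number from compound 1 to compound 2 (0.82 log units; beyond the scatter) does not bear on it, and no direction can be drawn from the data. The step of a 1.4-fold higher number from compound 2 to compound 3 (0.15 log units; within the scatter) is therefore expected to stay within the scatter. For compound 3 the estimate is 3000 nM, with a range from 1000 nM to 9000 nM.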

Compound 3, half-maximal inhibitory concentration: 24500 nM
Estimate against measurement, compound 3: 8.2-fold (0.91 log units) below; measured number above the stated range.
By their numbers in this assay, from the lowest: compound 2; then compounds 1 and 3 (each within the scatter of the next).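

The aryl group on a double-bonded chain carbon bound to a double-bonded chain carbon is not a neutral part of the series: in this assay, 3,5-dichlorophenyl in place of 4-bromophenyl gives a 12-fold higher number from compound 2 to compound 3 (1.07 log units; beyond the scatter). With the 3-methylbut-2-en-1-yl group unchanged, this change alone moves the number well beyond the scatter, and compound 2 keeps the lowest value.

This single step changes both the halogen and its ring positions, so the two changes cannot be separated. On these data alone, how 4-chlorophenyl, 3-chlorophenyl or an unsubstituted phenyl would read here remains open. No evidence on hand bears on the reason for this rise.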